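A few compounds are considered here, and "the series" means these few. Any claim that something is new, unique, unknown or untested is made for them only; others in the source may bear on it.

Compound 1, with the structure `CCCC(=O)OCSc1ccccc1C(=O)NCC(N)=O`, is tested in an ADME assay on CEM-SS cells (Homo sapiens) for cytotoxicity, read by XTT assay, with a stated time of 6 days; a lower number here means that less compound is tolerated, a higher number that more compound is tolerated. Its value there, > 100 uM, is a limit of the assay and not a number. The same core appears in compound 2, `CCCC(=O)OCSc1ccccc1C(=O)N[C@H]1CCC[C@H]1C(N)=O`, which gives 89.9 uM; 84.8 uM (2 entries) in this assay, and in compound 3, `CCCC(=O)OCSc1ccccc1C(=O)N[C@@H]1CCC[C@H]1C(N)=O`, which gives 43.7 uM. Among the compounds with values here, the one measured step, an at least 2.2-fold lower number from compound 1 to compound 3 (0.35 log units; beyond the scatter), moves away from the limit. Compounds 2 and 3 are related because of the fact that compounds 2 and 3 differ only in the configuration as drawn, and their two values simply show that the one with the configuration of compound 3 gives the lower number.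

Compound 4, `CCCC(=O)OCSc1ccccc1C(=O)N(C)CC(=O)N(C)C`, has not yet been measured. It differs from compound 1 by ((dimethylcarbamoyl)methyl)(methyl)amino in place of (carbamoylmethyl)amino on a carbonyl carbon. Within the data shown here, no measured step shows this kind of change; the only step known, from compound 1 to compound 3, involves a different replacement on the amide-type nitrogen and moved the number down by at least a modest amount. Among the measured compounds shown here, because of the limit of > 100 uM in this assay, at which 1 of the 3 values shown sits, compound 1 offers no single number to step from, so the expectation for compound 4 rests mostly on the spread of the three compounds, which all sit high. The step of an at least 1.5-fold lower number from compound 1 to compound 4 (0.18 log units; that floor lies within the scatter) is therefore expected to be modest and downward, if anything. Compound 4 is estimated to give 65 uM in this assay, within a range from 25 uM to 150 uM.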

Compound 4, half-maximal toxic concentration: 57.3 uM
Estimate against measurement, compound 4: 1.1-fold (0.05 log units) above; low and high end bracket the measured number.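

Compound 1 gives > 100 uM in this assay, which is a limit of the assay and not a number. On a carbonyl carbon whose other neighbour is an aromatic carbon, placing ((dimethylcarbamoyl)methyl)(methyl)amino where (carbamoylmethyl)amino stood, a change that adds no ring and leaves no hydrogen-bond donors in the group, gives an at least 1.7-fold lower number from compound 1 to compound 4 (0.24 log units; that floor lies within the scatter), so this open-chain change cannot be called a true drop, although the real gap may be larger. Unlike the earlier step, an at least 2.2-fold lower number from compound 1 to compound 3 (0.35 log units; beyond the scatter), this one does not clear the normal variation between repeated measurements, and it can be given only as a floor: the limit of > 100 uM in this assay, at which 1 of the 4 values shown sits.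

The compounds shown do not separate the effect of the methyl on the amide-type nitrogen from that of the methyl groups in the dimethylcarbamoyl part, since compound 4 carries both at once. As far as these compounds go, how a carboxylic acid or a longer carbon chain in place of the carbamoyl group would read in this assay also remains open.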